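Trifluoromethoxy in Place of Isopropyl on a Shared Core

This account rests on a few compounds, and the source may have more. Where it says the series, first, only, none or still open, it means among the compounds named here.

Compound 1 `CCc1ccccc1Nc1ncc2cc(Oc3ccnc(C(=O)NC)c3)ccc2n1`: in an ADME assay on Caco-2 cells (Homo sapiens) for permeability, in the apical to basolateral direction (on this read-out higher numbers stand for higher permeability and lower numbers for lower permeability), compound 1 gives < 1 10^-6 cm/s, which is a limit of the assay rather than a number.
Compound 2 `CNC(=O)c1cc(Oc2ccc3nc(Nc4ccc(Br)cc4)ncc3c2)ccn1`: in this assay compound 2 gives < 1 10^-6 cm/s, again a limit.
Compound 3 `CNC(=O)c1cc(Oc2ccc3nc(Nc4ccc(C(C)C)cc4)ncc3c2)ccn1`: in this assay compound 3 gives < 1 10^-6 cm/s, also a limit.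

Compound 3 thus stands where every measured compound in this set stands, at the limit: the limit of < 1 10^-6 cm/s in this assay, at which 3 of the 3 values shown sit. The three steps among the measured compounds, a step that the two limits leave unreadable from compound 1 to compound 2, a step that the two limits leave unreadable from compound 1 to compound 3 and a step that the two limits leave unreadable from compound 2 to compound 3, cannot be sized, since each compares one limit with another; changing the group on the aniline nitrogen from 2-ethylphenyl to 4-bromophenyl or 4-isopropylphenyl, or bromo to isopropyl, left no readable footprint.

Compound 4 `CNC(=O)c1cc(Oc2ccc3nc(Nc4ccc(OC(F)(F)F)cc4)ncc3c2)ccn1` differs from compound 3 in one place: trifluoromethoxy in place of isopropyl on an aromatic carbon. Among the compounds with values here, no measured step speaks to this exchange beyond those three unreadable ones, and all of them end at the limit. The expected step is therefore a step that the limit leaves unreadable from compound 3 to compound 4, most likely leaving compound 4 at the limit as well. Compound 4 is estimated to give 0.7 10^-6 cm/s, with a range from 0.2 10^-6 cm/s to 2.5 10^-6 cm/s.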

Compound 4, apparent permeability: < 1 10^-6 cm/s
Compound 4 gave a limit, no number; the forecaster's own chance of this, stated with the estimate: 70%; the middle value lies beyond the limit too.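

Compound 4 also gives a limit rather than a number, so its steps from compound 1, compound 2 and compound 3 cannot be read, as each compares one limit with another: the limit of < 1 10^-6 cm/s in this assay, at which 4 of the 4 values shown sit.

The compounds shown leave open how far apart these four really lie in this assay, and whether any group on the aniline nitrogen gives a measurable number.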